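Phenyl for Hexyl on the Chain of Compound 1

This account rests on a few compounds, and the source may have more. Where it says the series, first, only, none or still open, it means among the compounds named here.

In a functional assay on HeLa cells (Homo sapiens) for antiproliferative activity, read by MTT assay, with a stated time of 3 days (on this read-out higher numbers stand for weaker inhibition and lower numbers for stronger inhibition), compound 1 `CCCCCCCCC#Cc1cn(C/C=C\CN2C(=O)c3ccccc3C2=O)c(=O)[nH]c1=O` gives 59000 nM, the higher of the two numbers shown, and compound 3 `CCCCCc1ccc(C#Cc2cn(C/C=C/CN3C(=O)c4ccccc4C3=O)c(=O)[nH]c2=O)cc1` gives 27000 nM. Compound 2 `CCCCCCCCC#Cc1cn(C/C=C/CN2C(=O)c3ccccc3C2=O)c(=O)[nH]c1=O` reads > 100000 nM, which is a limit of the assay. Compound 4 `O=C1c2ccccc2C(=O)N1C/C=C\Cn1cc(C#CCCc2ccccc2)c(=O)[nH]c1=O` differs from compound 1 by phenyl in place of hexyl on a saturated chain carbon, two bonds along the chain from a triple-bonded carbon. The step of an at least 1.6-fold higher number from compound 1 to compound 2 (0.22 log units; that floor lies within the scatter) concerns configuration only the fact that compounds 1 and 2 differ only in the configuration as drawn and does not bear on this change. Among the compounds with values here, the closest precedent is an at least 3.7-fold lower number from compound 2 to compound 3 (0.56 log units; beyond the scatter), where 4-pentylphenyl replaced octyl on a triple-bonded carbon. That is a different change, so only a small move towards a lower number is expected, as a 1.7-fold lower number from compound 1 to compound 4 (0.23 log units; within the scatter). Compound 4 is estimated at 35000 nM, with an expected range from 14000 nM to 90000 nM.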

Compound 4, half-maximal inhibitory concentration: > 100000 nM
Compound 4 ended at the assay's limit (the forecaster's own chance of this, stated with the estimate: 15%); middle value at least 2.8-fold (0.45 log units) away from the limit.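

Phenyl in place of hexyl on a saturated chain carbon, two bonds along the chain from a triple-bonded carbon, gives an at least 1.6-fold higher number from compound 1 to compound 4 (0.22 log units; that floor lies within the scatter), so this change brought no lower number. The earlier step with an aromatic ring, on a triple-bonded carbon, went the other way, an at least 3.7-fold lower number from compound 2 to compound 3 (0.56 log units; beyond the scatter), so among these compounds such a ring does not bring a lower number wherever it sits, with compound 3 the one case that does show one. Compound 4 reads only as a limit, so the full size of its step cannot be told: the limit of > 100000 nM in this assay, at which 2 of the 4 values shown sit.

On these data alone, whether an amine, a carboxylic acid or a longer chain at this carbon would give a lower number stays open.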